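This account rests on a few compounds, and the source may have more. Where it says the series, first, only, none or still open, it means among the compounds named here.

Measured compounds:
compound 1, `CCC(=O)Nc1cc(C(=O)Nc2ccc(N3CCN(C)CC3)cc2)ccc1OC`: > 200000 nM
compound 2, `CC(C)Oc1ccc(C(=O)Nc2ccc(N(C)C)cc2)cc1[N+](=O)[O-]`: 50000 nM

In a toxicity assay on Huh-7.5 cells (Homo sapiens) for inhibition, read by MTT assay, with a stated time of 96 h (a lower number here means that less compound is tolerated, a higher number that more compound is tolerated), compound 1 gives > 200000 nM, which is a limit of the assay and not a number. Compound 2 gives 50000 nM in this assay. For the measured compounds named here, compound 1 thus sits at the limit of > 200000 nM in this assay, at which 1 of the 2 values shown sits, and no measured step between these two compounds exists. Compound 3, `CCC(=O)Nc1cc(C(=O)Nc2ccc(-c3cc4ccccc4[nH]3)cc2)ccc1OC`, carries 1H-indol-2-yl in place of 4-methylpiperazin-1-yl on an aromatic carbon. A step downward beyond the scatter is expected from this change, so that compound 3 is estimated at 50000 nM in this assay, within 15000 nM to 200000 nM, which would mean an at least 4.0-fold lower number from compound 1 to compound 3 (0.60 log units; beyond the scatter) as the expected step.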

Compound 3, half-maximal cytotoxic concentration: 65600 nM
Estimate against measurement, compound 3: 1.3-fold (0.12 log units) below; the measured number falls inside the stated range.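

For the compounds shown here, with 1H-indol-2-yl in place of 4-methylpiperazin-1-yl on an aromatic carbon, para to a large group, this assay now shows a first readable step at this position, an at least 3.0-fold lower number from compound 1 to compound 3 (0.48 log units; beyond the scatter), so the change does lower the number. Compound 1 stands at a limit of the assay, not a number, which leaves the step a bound and not an exact size: the limit of > 200000 nM in this assay, at which 1 of the 3 values shown sits.

Still open, from the compounds shown here alone, is whether phenyl or morpholin-4-yl at this position would give a number like that of compound 3, which would show whether the indole itself or only the departure of the 4-methylpiperazin-1-yl group goes with the step.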